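Rearranging an Amine Side Chain: Expected Mouse Potency

The compounds below may be only part of what the source reports. "The series", "measured", "known", "first", "only" and "open" are said of these compounds alone.

Measured compounds:
- Compound 1, `Cc1nnc(CN)n1-c1ccc(Cl)cc1C(O)c1ccccc1`: 9 mg/kg
- Compound 2, `Cc1nnc(CN(C)C)n1-c1ccc(Cl)cc1C(=O)c1ccccc1`: 5 mg/kg
- Compound 3, `Cc1nnc(CN2CCCC2)n1-c1ccc(Cl)cc1C(=O)c1ccccc1Cl`: 18 mg/kg

These three compounds were tested in a functional assay on the whole organism (strain CF-1) with Mus musculus as the target; on this read-out lower numbers stand for an effect already at smaller amounts and higher numbers for an effect only at larger amounts of compound. In this assay compound 2 gives 5 mg/kg, the lowest of the three numbers. Its gap to compound 1, which gives 9 mg/kg, falls within the usual scatter of repeated measurements, so the two cannot be told apart. Compound 3, with 18 mg/kg, lies beyond the scatter from compound 2.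

Compound 4, `CCNCc1nnc(C)n1-c1ccc(Cl)cc1C(=O)c1ccccc1`, has the same atoms as compound 2 joined differently: ethylamino in place of dimethylamino on a saturated chain carbon bound to an aromatic carbon. Going by the values given here, no directly comparable pair among the measured compounds shows what such a change does here; compound 1 carries a different amine and a different carbon link to the phenyl ring at the same time, so its value cannot be taken as a guide for this change alone. The expected step is a 1.2-fold higher number from compound 2 to compound 4 (0.08 log units; within the scatter), and it is expected to stay within the scatter rather than move clearly in either direction. Compound 4 is therefore estimated to give 6 mg/kg, with a range from 3 mg/kg to 15 mg/kg.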

Compound 4, dose for half-maximal effect: 2.5 mg/kg
Estimate against measurement, compound 4: 2.4-fold (0.38 log units) above; the measured number lies below the stated range.
By their numbers in this assay, from the lowest: compounds 4, 2, 1 and 3 (each within the scatter of the next, the first and the last beyond it).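

Read in this assay, placing ethylamino in the position of dimethylamino on a saturated chain carbon bound to an aromatic carbon gives a 2.0-fold lower number from compound 2 to compound 4 (0.30 log units; within the scatter) and so stays within the usual scatter of repeated measurements. Going by these compounds alone, this is the first direct comparison of two amines at this place, and it shows that the two arrangements of the same atoms cannot be told apart here, even though ethylamino has one hydrogen-bond donor and dimethylamino has none. Nothing available explains the size of this step.

As far as these compounds go, it remains open how a longer chain such as propylamino, or a piperidine ring, would read at this place. The amines of compound 1 and compound 3 each come with a further difference elsewhere, so neither can be compared on its amine alone.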